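Removing the methyl from the aryl ring of compound 3

The compounds below may be only part of what the source reports. "The series", "measured", "known", "first", "only" and "open" are said of these compounds alone.

Measured compounds:
compound 1, `Cc1ccc(NC(=S)NC(=O)c2cn(-c3ccccc3)nc2-c2ccc(F)cc2)cc1`, in a functional assay on A549 cells (Homo sapiens) for inhibition, read by CCK-8 assay, with a stated time of 48 h (on this read-out higher numbers stand for weaker inhibition and lower numbers for stronger inhibition), compound 1 gives 2080 nM
compound 2, `Cc1ccc(NC(=S)NC(=O)c2cn(-c3ccccc3)nc2-c2ccc(Cl)cc2)cc1`, in this assay compound 2 gives 2690 nM
compound 3, `Cc1ccc(NC(=S)NC(=O)c2cn(-c3ccccc3)nc2-c2ccc(C)cc2)cc1`, in this assay compound 3 gives 2830 nM

On the numbers shown, compound 3 carries the highest figure of the three, yet a 1.4-fold higher number from compound 1 to compound 3 (0.13 log units; within the scatter) and a 1.1-fold higher number from compound 2 to compound 3 (0.02 log units; within the scatter) are both within the scatter, so the three compounds cannot be separated on this read-out. The three measured steps, a 1.3-fold higher number from compound 1 to compound 2 (0.11 log units; within the scatter), a 1.4-fold higher number from compound 1 to compound 3 (0.13 log units; within the scatter) and a 1.1-fold higher number from compound 2 to compound 3 (0.02 log units; within the scatter), all exchange one group on the same aromatic carbon of the six-membered aromatic ring of carbon only, and none of them moves the number beyond the scatter.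

Compound 4, `Cc1ccc(NC(=S)NC(=O)c2cn(-c3ccccc3)nc2-c2ccccc2)cc1`, is not yet measured. It differs from compound 3 by hydrogen in place of methyl on an aromatic carbon, a change at the same place as the three measured steps. Since every exchange seen at this carbon stayed within the scatter, no step beyond the scatter is expected for a 1.0-fold lower number from compound 3 to compound 4 (0.00 log units; within the scatter) in this assay. The expected value for compound 4 in this assay is 2800 nM, with a range from 1400 nM to 5600 nM.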

Compound 4, half-maximal inhibitory concentration: 2800 nM
Compound 4: middle estimate and measured number agree at the digits printed, and the stated range covers the measured number.
By their numbers in this assay, from the lowest: compounds 1, 2, 4 and 3 (each within the scatter of the next).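

Taking the substituent away altogether gives a compound that cannot be told apart from the substituted ones in this assay: the steps are within the scatter (a 1.0-fold lower number from compound 3 to compound 4 (0.00 log units; within the scatter)), (a 1.0-fold higher number from compound 2 to compound 4 (0.02 log units; within the scatter)) and (a 1.3-fold higher number from compound 1 to compound 4 (0.13 log units; within the scatter)). The earlier compounds compared only fluoro, chloro and methyl, whereas compound 4 shows that, among these four compounds, the number does not depend on having any of these groups on this aromatic carbon. Nothing available explains why these four compounds cannot be separated.

As far as these compounds go, it remains open whether an amine, a carboxylic acid or a longer chain on this carbon would give a step beyond the scatter. Also open, from the compounds shown here alone, is how changes elsewhere would read, as all four compounds are identical outside this one place.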